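This account rests on a few compounds, and the source may have more. Where it says the series, first, only, none or still open, it means among the compounds named here.

Compound 1 `COc1cccc(Nc2nc(N)c(C(=O)c3ccccc3)s2)c1`: 5000 nM
Compound 2 `COc1ccc(C(=O)c2sc(Nc3ccccc3)nc2N)cc1OC`: > 10000 nM (a limit, not a number)
Compound 3 `COc1ccc(Nc2nc(N)c(C(=O)c3ccccc3)s2)cc1`: 730 nM

All three compounds were tested in a functional assay on FM3A cells (Mus musculus) for antiproliferative activity, read by cell counting, with a stated time of 2 days; a lower number here means a stronger inhibitor, a higher number a weaker inhibitor. Compound 3, at 730 nM, has the lower of the two exact numbers, and its gap to compound 1 lies beyond the scatter.

Compound 4 `COc1ccc(Nc2nc(N)c(C(=O)c3ccc(Cl)cc3)s2)cc1` differs from compound 3 by a chloro in place of hydrogen on an aromatic carbon, para to a large group, which turns phenyl into 4-chlorophenyl: chloro in place of hydrogen on an aromatic carbon. Going by the values given here, no measured pair differs in one place, so the data give no direct guide to this change. The expected change is small and its direction is uncertain, as in the estimated 1.1-fold higher number from compound 3 to compound 4 (0.04 log units; within the scatter). Compound 4 is expected at about 800 nM, within an estimated range of 200 nM to 3500 nM.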

Compound 4, half-maximal inhibitory concentration: 59 nM
Beside the measured number, compound 4's estimate is 14-fold (1.13 log units) above it; the whole stated range lies above it.
By their numbers in this assay, from the lowest: compound 4; then compound 3; then compound 1. At a limit, above all of these: compound 2.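

Turning phenyl into 4-chlorophenyl gives, in this assay, a 12-fold lower number from compound 3 to compound 4 (1.09 log units; beyond the scatter). This is the first pair shown that differs in one place, and it shows that this aromatic carbon is sensitive: one chlorine atom in place of hydrogen moves the number well beyond the scatter. Nothing shown accounts for the size of this step.

As far as these compounds go, whether the effect belongs to chloro alone stays open, since a fluoro, a methyl or an amine on the same carbon would be needed to tell. Also open, from the compounds shown here alone, is how chloro would act on the other carbons of that ring.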